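Alkene-linked series: hydantoin to thiazolidinedione exchange

The source may hold more compounds than are shown below. What is called first, only, known or untested is meant among the compounds shown, and "the series" means these compounds.

Within the data shown here, compound 3 `CC(C)C(/C=C1/C(=O)NC(=O)N1C)c1ccc(-c2ccc3cccc(F)c3c2)[nH]c1=O` gives the lowest number so far in a functional assay on CHO cells for antagonist activity at prostaglandin E2 receptor EP3 subtype (Homo sapiens), read by cAMP accumulation, with a stated time of 30 min (a higher number here means a weaker inhibitor, a lower number a stronger inhibitor), at 11 nM. Compound 2 `CC(C)C(c1ccc(-c2ccc3cccc(F)c3c2)[nH]c1=O)C1SC(=O)NC1=O` gives 110 nM and compound 1 `CC(C)C(c1ccc(-c2ccc3cccc(F)c3c2)[nH]c1=O)C1C(=O)NC(=O)N1C` gives 320 nM; the corresponding steps are a 10-fold lower number from compound 2 to compound 3 (1.00 log units; beyond the scatter) and a 29-fold lower number from compound 1 to compound 3 (1.46 log units; beyond the scatter). Compound 4 `CC(C)C(/C=C1\SC(=O)NC1=O)c1ccc(-c2ccc3cccc(F)c3c2)[nH]c1=O` differs from compound 3 by a group of 8 heavy atoms (4 carbon, 1 nitrogen, 2 oxygen, 1 sulfur; one five-membered non-aromatic ring with 2 hetero atoms) in place of a group of 9 heavy atoms (5 carbon, 2 nitrogen, 2 oxygen; one five-membered non-aromatic ring with 2 hetero atoms), on a saturated chain carbon bound to an aromatic carbon and a saturated chain carbon. The same exchange has been measured once on the saturated chain carbon, as a 2.9-fold lower number from compound 1 to compound 2 (0.46 log units; beyond the scatter), a modest gain. Among the measured compounds shown here, only that single step bears on the change, and it was measured without the double bond carried by compound 3 and compound 4, so a gain of similar modest size is expected, estimated as a 2.2-fold lower number from compound 3 to compound 4 (0.34 log units; beyond the scatter). Compound 4 is therefore expected to give about 5 nM, within 1.5 nM to 20 nM.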

Compound 4, half-maximal inhibitory concentration: 27 nM
For compound 4 the middle estimate is 5.4-fold (0.73 log units) below the measured one; measured number outside the range, above it.
By their numbers in this assay, from the lowest: compound 3; then compound 4; then compound 2; then compound 1.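

The ring exchange does not carry over between linkers: with the double bond it gives a 2.5-fold higher number from compound 3 to compound 4 (0.39 log units; beyond the scatter), opposite in direction to a 2.9-fold lower number from compound 1 to compound 2 (0.46 log units; beyond the scatter) on the saturated chain carbon. The double bond still pays with the sulfur-containing ring, at a 4.1-fold lower number from compound 2 to compound 4 (0.61 log units; beyond the scatter), though less than a 29-fold lower number from compound 1 to compound 3 (1.46 log units; beyond the scatter) with the nitrogen ring. Both changes together give a 12-fold lower number from compound 1 to compound 4 (1.07 log units; beyond the scatter), so the ring preference depends on the linker.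

No measurement here explains this reversal. As far as these compounds go, whether a carboxylic acid in place of either ring would follow either trend stays open.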